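Spiro-oxetane in place of dimethylazetidine on compound 3

This account rests on a few compounds, and the source may have more. Where it says the series, first, only, none or still open, it means among the compounds named here.

The series shares one core carrying a pyridin-2-yl group and an aryloxymethyl arm. Compound 1 `Cc1cc(COc2cccc(S(C)(=O)=O)c2)nc(-c2ccccn2)n1` reaches only the limit of a functional assay on cells for antagonist activity at Free fatty acid receptor 1 (Homo sapiens), read by TR-FRET and inositol phosphate accumulation, with a stated time of 2 h (a higher number here means a weaker inhibitor, a lower number a stronger inhibitor), giving > 39800 nM (the limit of > 39800 nM in this assay, at which 1 of the 3 values shown sits). Compound 2 `Cc1cc(COc2c(F)ccc(F)c2F)nc(-c2ccccn2)n1` gives 1580 nM in this assay. Compound 3 `CC1(C)CN(c2cc(COc3ccc(F)c(F)c3F)nc(-c3ccccn3)n2)C1` gives 25.1 nM in this assay, the lower of the two numbers, and its gap to compound 2 lies beyond the scatter.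

Compound 4 `Fc1ccc(OCc2cc(N3CC4(CCO4)C3)nc(-c3ccccn3)n2)c(F)c1F` differs from compound 3 in one place: a group of 7 heavy atoms (5 carbon, 1 nitrogen, 1 oxygen; 2 four-membered non-aromatic rings with 1 hetero atom each) in place of a group of 6 heavy atoms (5 carbon, 1 nitrogen; one four-membered non-aromatic ring with 1 hetero atom), on an aromatic carbon. Among the measured compounds shown here, no measured pair shows such a change, so no direction is firmly indicated; a step of no more than the usual scatter is expected, which is what the estimated step from compound 3 to compound 4 of a 1.6-fold higher number from compound 3 to compound 4 (0.20 log units; within the scatter) means. Compound 4 is therefore expected to give about 40 nM in this assay, with a likely range from 10 nM to 160 nM.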

Compound 4, half-maximal inhibitory concentration: 501 nM
Estimate against measurement, compound 4: 13-fold (1.10 log units) below, and the stated range ends below it.
By their numbers in this assay, from the lowest: compound 3; then compound 4; then compound 2. At a limit, above all of these: compound 1.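

Among the compounds shown here, the 3,3-dimethylazetidin-1-yl group on this aromatic carbon gave the first single-place comparison, and the position proved sensitive to a small change. Replacing it with the spiro-oxetane group, which keeps the azetidine ring and brings in a ring oxygen and a second four-membered ring, gave a 20-fold higher number from compound 3 to compound 4 (1.30 log units; beyond the scatter) in this assay. Nothing measured here gives a reason for this step.

The compounds shown leave open whether the oxygen or the added ring accounts for the step, which a spiro-cyclobutane, with carbon in place of the oxetane oxygen, could separate. They also leave open how a morpholine or a simple dimethylamino group at the same position would read in this assay.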